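Methylsulfanyl for methoxy on the aromatic ring of compound 2

The compounds below may be only part of what the source reports. "The series", "measured", "known", "first", "only" and "open" are said of these compounds alone.

Compound 1 `COc1ccc(CNc2nc([Se]C)nc3ccccc23)cc1` and compound 2 `COc1ccc(CNc2nc([SeH])nc3ccccc23)cc1` share one core and differ only on a selenium. In an ADME assay on BEAS-2B cells (Homo sapiens) for cytotoxicity, read by MTT assay, with a stated time of 72 h (a lower number here means a stronger inhibitor of growth, a higher number a weaker inhibitor of growth), compound 1 gives a limit of the assay, > 100000 nM. In this assay compound 2 likewise gives only a limit, > 100000 nM. The step that the two limits leave unreadable from compound 1 to compound 2 therefore cannot be read. Compound 3 `CCCCC[Se]c1nc([Se]CCCCC)c2ccccc2n1` also gives a limit in this assay, > 100000 nM. Where compound 2 stands is fixed only by the limit of > 100000 nM in this assay, at which 3 of the 3 values shown sit; no compound in the set has yet given a number.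

Compound 4 `CSc1ccc(CNc2nc([SeH])nc3ccccc23)cc1` differs from compound 2 by methylsulfanyl in place of methoxy on an aromatic carbon. Among the measured compounds shown here, no measured step bears on this change: the single step between measured compounds is unreadable, and every value shown sits at the limit. For compound 4 the expected step that the limit leaves unreadable from compound 2 to compound 4 is none beyond the scatter. Compound 4 is therefore estimated at 150000 nM, with a range of 40000 nM to 600000 nM, and most probably again only a limit.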

Compound 4, concentration for total growth inhibition: 58200 nM
The estimate for compound 4 lay 2.6-fold (0.41 log units) above the measured number, and the stated range covers the measured number.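

Among the compounds shown here, compound 4 is the first in the set to give a number in this assay, 58200 nM, so this position on the aromatic ring, para to a large group, is the first place where a change gives a reading rather than a limit. Methylsulfanyl in place of methoxy gives an at least 1.7-fold lower number from compound 2 to compound 4 (0.23 log units; that floor lies within the scatter), which fixes only a floor for the step and not its true size. The step on the selenium cannot be read, and most of the set still gives no number: the limit of > 100000 nM in this assay, at which 3 of the 4 values shown sit.

Open, as far as these compounds go, is how large the step from methoxy to methylsulfanyl really is, and whether it holds with methyl rather than hydrogen on the selenium. Also open, from the compounds shown here alone, is whether a longer sulfur chain such as ethylsulfanyl, or a dimethylamino group, at this position would give a lower number than compound 4.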